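This account rests on a few compounds, and the source may have more. Where it says the series, first, only, none or still open, it means among the compounds named here.

Measured compounds in a functional assay for agonist activity at sphingosine 1-phosphate receptor 5 (Homo sapiens); on this read-out higher numbers stand for an effect only at larger amounts of compound and lower numbers for an effect already at smaller amounts:
compound 1 `C/N=C1\S/C(=C\c2cc(C)n(Cc3ccccc3F)c2C)C(=O)N1C` gives 51 nM
compound 3 `C/N=C1\S/C(=C\c2cc(C)n(-c3ccc(F)cc3)c2C)C(=O)N1C` gives 652 nM
compound 2 `CC/N=C1\S/C(=C\c2cc(C)n(-c3ccc(F)cc3F)c2C)C(=O)N1CC` gives 6180 nM

Compound 1 has the lowest number of the three; the nearest is compound 3, and the furthest is compound 2. Among the compounds with values here, the one single-place step among them is a 13-fold higher number from compound 1 to compound 3 (1.11 log units; beyond the scatter), which swaps the benzyl attachment on the ring nitrogen for a directly bound aryl. Compound 2 combines the ethyl imine and ethyl amide substituents with a 2,4-difluorophenyl on that nitrogen, and with two sites changed against compound 3 nothing more can be read from its value than that it sits highest.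

Compound 4 `C/N=C1\S/C(=C\c2cc(C)n(Cc3ccc(F)cc3F)c2C)C(=O)N1C` keeps the benzyl attachment and the methyl groups of compound 1; the change is fluoro in place of hydrogen on an aromatic carbon. Within the data shown here, no measured step touches this position on the benzyl ring: the only comparison of ring substitution, between compound 3 and compound 2, is confounded by the imine and amide alkyls and by the change from benzyl to aryl. With the benzyl linker retained, the step of a 1.4-fold higher number from compound 1 to compound 4 (0.14 log units; within the scatter) is expected to stay within the usual scatter or to be small. Compound 4 is estimated at 70 nM (range 25 nM to 200 nM) in this assay.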

Compound 4, half-maximal effective concentration: 37 nM
For compound 4 the middle estimate is 1.9-fold (0.28 log units) above the measured one; measured number inside the range.
By their numbers in this assay, from the lowest: compounds 4 and 1 (each within the scatter of the next); then compound 3; then compound 2.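

In this assay the change from 2-fluorophenyl to 2,4-difluorophenyl on the benzyl group gives a 1.4-fold lower number from compound 1 to compound 4 (0.14 log units; within the scatter) and so stays within the scatter. Within the data shown here, this is the first reading of ring substitution free of other changes: an aromatic carbon para to a large group and meta to a fluoro group takes a fluoro with no change that can be told from the scatter, whereas the swap of benzyl for directly bound aryl gives a 13-fold higher number from compound 1 to compound 3 (1.11 log units; beyond the scatter) and lies beyond it. Nothing available explains why the number holds at this position.

Open, as far as these compounds go, is whether this carbon also accepts groups other than fluoro, such as chloro, methoxy, trifluoromethyl, an amine or a carboxylic acid, with the number in this assay still held. Also open, from the compounds shown here alone, is whether the same fluoro step reads the same way on a directly bound aryl or alongside the ethyl imine and ethyl amide substituents of compound 2, since compound 2 differs from compound 3 in more than one place.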